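This account rests on a few compounds, and the source may have more. Where it says the series, first, only, none or still open, it means among the compounds named here.

For the measured compounds named here, in a functional assay on A549 cells (Homo sapiens) for antiproliferative activity, read by MTT assay, with a stated time of 96 h (on this read-out lower numbers stand for stronger inhibition of growth and higher numbers for weaker inhibition of growth), compound 1 `CCCc1cc(-c2ccc(F)cc2)nn1Cc1ccc(C(=O)NO)cc1` gives 15200 nM, the only exact number available for this small set of hydroxycarbamoyl compounds. Compound 2 `O=C(CCCNC(=O)c1cc(-c2ccc(F)cc2)[nH]n1)NO` reads > 100000 nM in this assay, and this is a limit of the assay, not a number. Its true position is therefore unknown, and any step that starts from it is uncertain.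

Compound 3 `O=C(CCCCNC(=O)c1cc(-c2ccc(F)cc2)[nH]n1)NO` differs from compound 2 only in its chain: (hydroxycarbamoyl)methyl in place of hydroxycarbamoyl on a saturated chain carbon, three bonds along the chain from an amide-type nitrogen. Put simply, (hydroxycarbamoyl)methyl stands in place of hydroxycarbamoyl on a saturated chain carbon, three bonds along the chain from an amide-type nitrogen. Read one bond further out, this is 2-(hydroxycarbamoyl)ethyl to 3-(hydroxycarbamoyl)propyl.

Going by the values given here, no measured pair shows what such a change does in this assay, so only a modest shift towards stronger inhibition of growth is expected, and compound 3 may well remain at the limit too. The estimated size of this shift, an at least 1.6-fold lower number from compound 2 to compound 3 (0.22 log units; that floor lies within the scatter), is tentative. The expected value should stay weaker than compound 1 at 15200 nM. Compound 3 is estimated at 60000 nM, with an expected range of 20000 nM to 120000 nM.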

Compound 3, concentration for 50% growth inhibition: > 100000 nM
Compound 3 was reported as a limit (the forecaster's own chance of this, stated with the estimate: 45%); at least 1.6-fold (0.22 log units) between middle value and limit.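

Compound 2 and compound 3 both stand at a limit in this assay, not at a number, so no step can be read between them: the limit of > 100000 nM in this assay, at which 2 of the 3 values shown sit.

What the compounds shown leave open is whether (hydroxycarbamoyl)methyl in place of hydroxycarbamoyl on a saturated chain carbon, three bonds along the chain from an amide-type nitrogen, changes inhibition of growth in this assay at all, and in which direction.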